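Aryl methyl removal in sulfonylpiperidine antiproliferatives

This account rests on a few compounds, and the source may have more. Where it says the series, first, only, none or still open, it means among the compounds named here.

Compound 1 `Cc1cc(C)c(S(=O)(=O)N2CCC(c3ccccc3)CC2)c(C)c1`, compound 2 `Cc1ccc(C2CCN(S(=O)(=O)c3c(C)cc(C)cc3C)CC2)cc1` and compound 3 `Cc1ccc(S(=O)(=O)N2CCC(N3CCC(C)CC3)CC2)cc1C` have been measured in a functional assay on DLD-1 cells (Homo sapiens) for antiproliferative activity, read by CellTiter-Glo, with a stated time of 72 h; a lower number here means a stronger inhibitor, a higher number a weaker inhibitor. Compound 1 reaches only the limit > 5000 nM, which is a limit of the assay and not a number (the limit of > 5000 nM in this assay, at which 1 of the 3 values shown sits). In this assay compound 2 gives 2200 nM and compound 3 gives 24 nM. How the core of compound 3 differs from that of compound 2 is not broken down here. Compound 4 `Cc1cccc(S(=O)(=O)N2CCC(N3CCC(C)CC3)CC2)c1` awaits measurement in this assay.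

From compound 2 to compound 1 the change is hydrogen in place of methyl on an aromatic carbon and it gives an at least 2.2-fold higher number from compound 2 to compound 1 (0.35 log units; beyond the scatter). From compound 3 to compound 4 the change is hydrogen in place of methyl on an aromatic carbon, the same kind of change, but here the place is ortho to a methyl group as well as para to a large group. Resting on an at least 2.2-fold higher number from compound 2 to compound 1 (0.35 log units; beyond the scatter), the number for compound 4 is expected to move by a 2.7-fold higher number from compound 3 to compound 4 (0.43 log units; beyond the scatter). Compound 4 is therefore estimated at 65 nM. For compound 4 the expected range runs from 20 nM to 220 nM.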

Compound 4, half-maximal inhibitory concentration: 25 nM
Compound 4: the middle estimate sits 2.6-fold (0.41 log units) above what was measured; measured number inside the range.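

In this assay the step from 3,4-dimethylphenyl to 3-methylphenyl gives a 1.0-fold higher number from compound 3 to compound 4 (0.02 log units; within the scatter) and so compound 3 and compound 4 cannot be told apart on this core. Set beside the earlier step, the same replacement of methyl by hydrogen reads: the same change on two cores in this assay, an at least 2.2-fold higher number (0.35 log units; beyond the scatter) from compound 2 to compound 1 and a 1.0-fold higher number (0.02 log units; within the scatter) from compound 3 to compound 4; the limit leaves it open whether they differ. Compound 1 stands at > 5000 nM, which is a limit and not a number, so these two cores neither show that the step carries over from one to the other nor show that it does not.

Still open, as far as these compounds go, is how a chloro or methoxy group in place of the remaining methyl of compound 4 would read. Also open, from the compounds shown here alone, is how an unsubstituted phenyl would compare on the same core.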